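The compounds below may be only part of what the source reports. "The series", "measured", "known", "first", "only" and "open" are said of these compounds alone.

Measured compounds:
Compound 1 `C#CCn1cc(C(=O)NC(CC(=O)Nc2ccccc2)c2ccccc2)c(=O)c2cc(F)c(Cl)nc21` gives > 10000 nM in a functional assay on KB cells (Homo sapiens) for cytotoxicity, read by MTT assay, with a stated time of 72 h (on this read-out lower numbers stand for stronger inhibition and higher numbers for weaker inhibition), which is a limit of the assay rather than a number.
Compound 2 `C#CCn1cc(C(=O)NC(CC(=O)NC2CCCCC2)c2ccccc2)c(=O)c2cc(F)c(Cl)nc21` gives > 10000 nM in this assay, again a limit.
Compound 3 `C#CCn1cc(C(=O)NC(CC(=O)Nc2ccccc2)c2ccccc2)c(=O)c2cccnc21` gives > 10000 nM in this assay, again a limit.

Compound 1 therefore stands only at a limit: the limit of > 10000 nM in this assay, at which 3 of the 3 values shown sit, so none of the three compounds has a readable number. The change leading to compound 4 `C#CCn1cc(C(=O)NC(CC(=O)NC2CCCC2)c2ccccc2)c(=O)c2cc(F)c(Cl)nc21` is cyclopentyl in place of phenyl on an amide-type nitrogen. Among the compounds with values here, the one measured step that bears on it is a step that the two limits leave unreadable from compound 1 to compound 2, which exchanges the same phenyl for a cyclohexyl and runs from one limit to another, so its size cannot be read. With every value sitting at the limit, there is no footing for expecting a step beyond the scatter in either direction in this assay. Compound 4 is therefore expected to sit at the same limit, and the step that the limit leaves unreadable from compound 1 to compound 4 is estimated to be nothing readable. The estimate for compound 4 is 20000 nM, with a range from 10000 nM to 60000 nM, most likely again reported only as a limit.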

Compound 4, half-maximal inhibitory concentration: 4900 nM
Compound 4: the middle estimate sits 4.1-fold (0.61 log units) above what was measured; measured number outside the range, below it.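

Compound 4 gives the first readable number in this assay, so a change on this amide-type nitrogen can bring a compound off the limit, where the others remain: the limit of > 10000 nM in this assay, at which 3 of the 4 values shown sit.

Cyclopentyl in place of phenyl gives an at least 2.0-fold lower number from compound 1 to compound 4 (0.30 log units; that floor lies within the scatter), and cyclopentyl in place of cyclohexyl gives an at least 2.0-fold lower number from compound 2 to compound 4 (0.30 log units; that floor lies within the scatter). Both the aromatic ring and the larger non-aromatic ring therefore leave their compounds at a limit, while the five-membered ring of carbon gives a number, though each step is known only as a floor.

As far as these compounds go, the true size of both steps stays open, with a limit at the starting end of each. Also open, from the compounds shown here alone, are whether a smaller ring such as cyclopropyl or an open chain such as butyl on this nitrogen gives a readable number, and whether cyclopentyl keeps a number on the core of compound 3.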